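This account rests on a few compounds, and the source may have more. Where it says the series, first, only, none or still open, it means among the compounds named here.

Measured compounds:
Compound 1 `COc1cc(C)cc(-c2c(-c3ccnc(-c4ccc(N(C)C)cc4)c3)cnn2CC#N)c1` gives 44% in a functional assay on SNB-19 cells (Homo sapiens) for cytotoxicity, read by sulforhodamine B assay, with a stated time of 48 h, tested at 0.01 uM; on this read-out lower numbers stand for a stronger effect and higher numbers for a weaker effect at the one concentration tested.
Compound 2 `Cc1cc(O)cc(-c2nn(CC#N)cc2-c2ccnc(-c3ccc(N(C)C)cc3)c2)c1` gives 95% in this assay.

Among these two numbers, compound 1 stands at the lowest value, which on this read-out stands for the stronger effect. Compound 2 lies far above it, and the gap is beyond the usual scatter of the method. Among the compounds with values here, the two compounds differ in more than one place, however, and no single step connects them, so their pair shows nothing more than its two values.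

The unmeasured compound 3 `COc1cc(C)cc(-c2c(-c3ccnc(-c4ccc(C(C)=O)cc4)c3)cnn2CC#N)c1` follows from compound 1 by a single change: acetyl in place of dimethylamino on an aromatic carbon. Within the data shown here, no measured pair shows this same change, so the measured compounds give no guide to the size of the step. In the absence of such a guide, the expected step of a number 18 percentage points higher from compound 1 to compound 3 (beyond the scatter) is a moderate move toward higher numbers, that is toward a weaker effect, probably somewhat beyond the scatter, with wide uncertainty. Compound 3 is accordingly estimated at 62%, with a range from 35% to 92%.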

Compound 3, a percentage reported as activity, at one concentration (the size of the read-out at that concentration, not a potency): 102%
Estimate against measurement, compound 3: 40 percentage points below; the measured number lies above the stated range.
By their numbers in this assay, from the lowest: compound 1; then compounds 2 and 3 (each within the scatter of the next).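

Within this assay, the single change of 4-(dimethylamino)phenyl to 4-acetylphenyl gives a number 58 percentage points higher from compound 1 to compound 3 (beyond the scatter), the first step in this series that can be read at one place, and it shows that the read-out at the one concentration tested is highly sensitive to the group on this aromatic carbon. The two groups match in heavy-atom count and in their counts of hydrogen-bond donors and acceptors, so those counts do not track this large step, and the lower number of compound 1 depends on dimethylamino being present rather than on any group of that size at this place. Nothing available here bears on the reason for this step.

As far as these compounds go, whether a smaller amine such as a primary amino or methylamino group, a longer diethylamino group, or a carboxylic acid at this same place would keep the number near that of compound 1 remains open. Also open, from the compounds shown here alone, is what the rest of the core of compound 1 contributes, since compound 2 differs from it in more than one place.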